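The source may report more compounds than this note shows. Statements on the series, on what has been measured and on what is new or still open speak of the compounds shown alone.

Measured compounds, in a functional assay on EA.hy 926 cells (Homo sapiens) for cytotoxicity, read by MTT assay, with stated times of 24 h and 12 h, tested at 12.5 uM; on this read-out lower numbers stand for a weaker effect and higher numbers for a stronger effect at the one concentration tested:

- compound 1 `Cc1nc(C)c(C(=O)Oc2ccc(/C=C/C(=O)O)cc2O)nc1C` gives 92.8%
- compound 2 `CCOC(=O)/C=C/c1cc(Cl)ccc1OC(=O)c1nc(C)c(C)nc1C` gives 64.9%
- compound 3 `COc1ccc(/C=C/C(=O)O)c(OC(=O)c2nc(C)c(C)nc2C)c1` gives 39.7%

Compound 1 stands highest of the three numbers. Its nearest neighbour, compound 2, sits lower by a gap beyond the scatter, and compound 3 sits lowest, a gap from compound 1 that is also beyond the scatter. Within the data shown here, compounds 2 and 3 each differ from compound 1 in more than one place, so no pair of measured compounds separates a single structural change, and no measured step size is available.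

Compound 4 `Cc1nc(C)c(C(=O)Oc2ccc(/C=C/C(=O)O)cc2)nc1C` is unmeasured. It differs from compound 1 by hydrogen in place of hydroxy on an aromatic carbon, the hydroxy leaving and hydrogen entering on the shared core. Among the measured compounds shown here, with no single-change step in hand, the expectation rests on compound 1 alone. The step of a number 14.8 percentage points lower from compound 1 to compound 4 (beyond the scatter) is expected to be small, downward or not beyond the scatter, since the large group and the 2-carboxyethenyl group are retained. Compound 4 is therefore estimated at 78%, with a range from 55% to 95%.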

Compound 4, a percentage reported as activity, at one concentration (the size of the read-out at that concentration, not a potency): 34.2%
Beside the measured number, compound 4's estimate is 43.8 percentage points above it; the whole stated range lies above it.
By their numbers in this assay, from the lowest: compounds 4 and 3 (each within the scatter of the next); then compound 2; then compound 1.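

In this assay, hydrogen in place of hydroxy on this aromatic carbon, ortho to a large group and meta to a 2-carboxyethenyl group, gives a large step, a number 58.6 percentage points lower from compound 1 to compound 4 (beyond the scatter). Among these compounds, this is the first single-change step, and it shows that keeping the large group and the 2-carboxyethenyl group does not by itself hold the number when this one hydroxy leaves. Nothing available explains why the removal of this single oxygen atom moves the read-out so far.

Still open, from the compounds shown here alone, is whether the hydroxy itself is needed or whether an amine, a methoxy or a fluorine on the same aromatic carbon would hold the number. Also open, going by these compounds, is whether a step of this size would recur with a longer chain in place of the 2-carboxyethenyl group.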